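Swapping carboxy for 2-aminoethyl on a chain carbon

The source may report more compounds than this note shows. Statements on the series, on what has been measured and on what is new or still open speak of the compounds shown alone.

Compound 1, `NCCCC[C@H](NC(=O)CN(c1nc(Cl)nc2[nH]cnc12)C1CC1)C(=O)OCc1ccccc1`, gives 41.2% in a functional assay on the whole organism (Tail, strain ICR) with Mus musculus as the target, in the tail flick test, with a stated time of 60 min, at a dose of 25 umol/kg by the oral route; on this read-out higher numbers stand for a stronger effect at the one dose given and lower numbers for a weaker effect.
Compound 2, `O=C(O)CC[C@H](NC(=O)CN(c1nc(Cl)nc2[nH]cnc12)C1CC1)C(=O)O`, gives 33.3% in this assay.

Compound 2 holds the lower of these two numbers, yet the gap to compound 1 is within the scatter, so the two are not separated. Compound 3, `NCCCC[C@H](NC(=O)CN(c1nc(Cl)nc2[nH]cnc12)C1CC1)C(=O)O`, differs from compound 2 in one place: 2-aminoethyl in place of carboxy on a saturated chain carbon, three bonds along the chain from an amide-type nitrogen and a carbonyl carbon. Within the data shown here, no step between measured compounds is available, and the two numbers give no sign of a change beyond the scatter, so the step from compound 2 to compound 3 is expected to be a number 3.7 percentage points higher from compound 2 to compound 3 (within the scatter). Compound 3 is estimated at 37%, with a range of 20% to 55%.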

Compound 3, a percentage reported as activity, at one dose (the size of the read-out at that dose, not a potency): 53.8%
For compound 3 the middle estimate is 16.8 percentage points below the measured one; low and high end bracket the measured number.
By their numbers in this assay, from the lowest: compounds 2 and 1 (each within the scatter of the next); then compound 3.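

In this assay, the group on this saturated chain carbon proves to matter: 2-aminoethyl in place of carboxy gives a number 20.5 percentage points higher from compound 2 to compound 3 (beyond the scatter), a separation the first two compounds could not show. Hydrogen in place of benzyl on the oxygen next to a carbonyl group also gives a number 12.6 percentage points higher from compound 1 to compound 3 (beyond the scatter), so the free carboxylic acid outscores its benzyl ester here. Nothing available accounts for either step. As far as these compounds go, whether a shorter or longer amine chain on this carbon would do the same remains open, as does how a methyl ester would compare on that oxygen.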